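Heteroaryl ketones on the oleoyl chain: working notes

The compounds below may be only part of what the source reports. "The series", "measured", "known", "first", "only" and "open" are said of these compounds alone.

Compound 3 `CCCCCCCC/C=C\CCCCCCCC(OC)OC` ends in the 2,2-dimethoxyethyl group. In an assay on isolated protein for inhibition of Fatty-acid amide hydrolase 1 (Homo sapiens) (on this read-out lower numbers stand for stronger inhibition and higher numbers for weaker inhibition), compound 3 is reported only as a limit of the assay, > 300000 nM, and not as a number. Compound 3 thus sits at the limit of > 300000 nM in this assay, at which 1 of the 3 values shown sits. For orientation, compound 1 `CCCCCC(=O)C(F)(F)F` gives 28900 nM in this assay, while compound 2 `CCCCCCCC/C=C\CCCCCCC(=O)c1nc(-c2ccccn2)co1` gives 31 nM. Compound 4 `CCCCCCCC/C=C\CCCCCCC(=O)c1cccnn1` is not yet measured and differs from compound 3 by (pyridazin-3-yl)carbonyl in place of 2,2-dimethoxyethyl on a saturated chain carbon, six bonds along the chain from a double-bonded chain carbon. A step far beyond the scatter towards stronger inhibition is expected, since compound 2 with a heteroaryl ketone on the same chain gives 31 nM. The estimated step is an at least 1000-fold lower number from compound 3 to compound 4 (3.00 log units; beyond the scatter). Compound 4 is expected at 300 nM, with a range from 50 nM to 2000 nM.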

Compound 4, inhibition constant: 130 nM
Compound 4: middle estimate off by 2.3-fold (0.36 log units), on the high side; low and high end bracket the measured number.
By their numbers in this assay, from the lowest: compound 2; then compound 4; then compound 1. At a limit, above all of these: compound 3.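

In this assay, (pyridazin-3-yl)carbonyl in place of 2,2-dimethoxyethyl on a saturated chain carbon, six bonds along the chain from a double-bonded chain carbon, gives an at least 2300-fold lower number from compound 3 to compound 4 (3.36 log units; beyond the scatter). Compound 2 was previously the only heteroaryl ketone on this chain; a ketone carrying a six-membered aromatic ring with 2 hetero atoms now also reads far from the limit. The true size of the step stays unknown because compound 3 is only a limit: the limit of > 300000 nM in this assay, at which 1 of the 4 values shown sits.

A phenyl ketone or a carboxylic acid at this place would help separate the contribution of the carbonyl from that of the ring nitrogens. On these data alone, how a longer chain would read with the (pyridazin-3-yl)carbonyl group also remains open.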